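Methyl on an aromatic nitrogen of compound 2

The source may hold more compounds than are shown below. What is called first, only, known or untested is meant among the compounds shown, and "the series" means these compounds.

Among the compounds with values here, in a functional assay on HeLa cells (Homo sapiens) for antiproliferative activity, read by MTT assay, with a stated time of 48 h (on this read-out lower numbers stand for stronger inhibition and higher numbers for weaker inhibition), compound 2 `CN(C)CCn1c(N)c(-c2nc3ccccc3[nH]2)c2nc(C#N)c(C#N)nc21` gives 8880 nM, the only true number so far. Compound 1 `CCn1c(N)c(-c2nc3ccccc3[nH]2)c2nc(C#N)c(C#N)nc21` reaches only a limit of the assay, > 50000 nM. Compound 3 `CN(C)CCn1c(N)c(-c2nc3ccccc3s2)c2nc(C#N)c(C#N)nc21` also reaches only a limit, > 50000 nM.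

Compound 4 `CN(C)CCn1c(N)c(-c2nc3ccccc3n2C)c2nc(C#N)c(C#N)nc21` makes one change to compound 2, methyl in place of hydrogen on an aromatic nitrogen.

The closest evidence is an at least 5.6-fold higher number from compound 2 to compound 3 (0.75 log units; beyond the scatter), where 1,3-benzothiazol-2-yl replaced 1H-benzimidazol-2-yl and that hydrogen was also lost. The other step, an at least 5.6-fold lower number from compound 1 to compound 2 (0.75 log units; beyond the scatter), changed the chain instead, so it bears less directly. A move towards weaker inhibition is therefore expected, with an estimated 2.8-fold higher number from compound 2 to compound 4 (0.45 log units; beyond the scatter). The expected value for compound 4 is 25000 nM, within a range of 9000 nM to 50000 nM.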

Compound 4, half-maximal inhibitory concentration: > 50000 nM
Compound 4: a limit, no number (the forecaster's own chance of this, stated with the estimate: 45%); at least 2.0-fold (0.30 log units) between middle value and limit.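

In this assay, methyl in place of hydrogen on an aromatic nitrogen gives an at least 5.6-fold higher number from compound 2 to compound 4 (0.75 log units; beyond the scatter). Compound 3 lost this hydrogen only by exchanging the whole 1H-benzimidazol-2-yl group, whereas compound 4 keeps that ring system and alters just this one atom, so the weakening can now be tied to this position. The full size of the step cannot be read, since compound 4 gives only a limit: the limit of > 50000 nM in this assay, at which 3 of the 4 values shown sit.

From the compounds shown here alone, whether an ethyl group or a longer chain ending in an amine on this nitrogen would behave like methyl remains open.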